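The source may report more compounds than this note shows. Statements on the series, on what has been measured and on what is new or still open speak of the compounds shown alone.

Working notes on the series.

Compound 1 `COc1ccc(/C=C/C(=O)c2ccccc2-c2ccc(F)cc2)cc1OC` gives 95 nM in a functional assay on HepG2 cells (Homo sapiens) for antiproliferative activity, read by sulforhodamine B assay, with a stated time of 48 h; on this read-out higher numbers stand for weaker inhibition and lower numbers for stronger inhibition. Compound 2 `COc1ccc(/C=C/C(=O)c2ccccc2-c2ccc(F)nc2)cc1OC` differs from it by 6-fluoropyridin-3-yl in place of 4-fluorophenyl on an aromatic carbon and gives 1000 nM; this one change produces an 11-fold higher number from compound 1 to compound 2 (1.02 log units; beyond the scatter). Compound 3 `COc1ccc(C(=O)/C=C/c2ccccc2-c2ccc(F)cc2)cc1` is built on a different core; how its core differs from the core of compound 1 is not broken down here. In this assay compound 3 gives 6300 nM, the highest number among the three measured compounds.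

Compound 4 `COc1ccc(C(=O)/C=C/c2ccccc2-c2ccc(F)nc2)cc1` is not yet measured. It stands to compound 3 as compound 2 stands to compound 1: the change is 6-fluoropyridin-3-yl in place of 4-fluorophenyl on an aromatic carbon, and the place is described in the same words for both pairs, so it is the same change. Among the compounds with values here, the only precedent is the step from compound 1 to compound 2, which sets an expectation of a sizable increase. As compound 3 already starts high, an expected step of a 4.8-fold higher number from compound 3 to compound 4 (0.68 log units; beyond the scatter) is taken as the working assumption in this assay, somewhat smaller than the precedent since the read-out may approach its upper range. Compound 4 is therefore expected to give about 30000 nM, roughly between 8000 nM and 100000 nM, in this assay.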

Compound 4, half-maximal inhibitory concentration: 8200 nM
Beside the measured number, compound 4's estimate is 3.7-fold (0.56 log units) above it; measured number inside the range.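

In this assay, 6-fluoropyridin-3-yl in place of 4-fluorophenyl on the core of compound 3 gives a 1.3-fold higher number from compound 3 to compound 4 (0.11 log units; within the scatter), so the large step seen on the core of compound 1 does not reappear here. The size of this change therefore does not carry over from one core to the other in this series: the same change on two cores in this assay, an 11-fold higher number (1.02 log units; beyond the scatter) from compound 1 to compound 2 and a 1.3-fold higher number (0.11 log units; within the scatter) from compound 3 to compound 4, 8.1-fold (0.91 log units) apart, beyond the scatter of two such steps. Within the data shown here, this does not show which feature of the cores sets the difference between the two steps, and with only two pairs it gives no rule for any further core.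

The compounds shown leave open which part of the core decides how much the swap from 4-fluorophenyl to 6-fluoropyridin-3-yl matters. They also leave open whether a different group at the same place, such as an amine or a carboxylic acid on the aromatic ring in place of the fluorine, would give steps that agree or disagree between the two cores.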